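Removing the Side Chain From Compound 1

The compounds below may be only part of what the source reports. "The series", "measured", "known", "first", "only" and "open" are said of these compounds alone.

- Compound 1 `CN1CCN(c2ccc(Nc3ncc4nc(Nc5ccc(F)cc5)n([C@@H]5CCN(C(=O)CO)C5)c4n3)cc2)CC1`: 350 nM
- Compound 2 `CN1CCN(c2ccc(Nc3ncc4nc(Nc5ccc(F)cc5)n(-c5cccc(NC(=O)CO)c5)c4n3)cc2)CC1`: 7.5 nM

In a functional assay on HCC827 cells (Homo sapiens) for antiproliferative activity, read by MTT assay, with a stated time of 72 h (a lower number here means a stronger inhibitor, a higher number a weaker inhibitor), compound 1 gives 350 nM, the higher of the two numbers, which makes it the weaker inhibitor of the pair. Going by the values given here, the only measured step, a 47-fold lower number from compound 1 to compound 2 (1.67 log units; beyond the scatter), puts 3-(((hydroxymethyl)carbonyl)amino)phenyl in place of 1-((hydroxymethyl)carbonyl)pyrrolidin-3-yl on an aromatic nitrogen.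

Compound 3 `CN1CCN(c2ccc(Nc3ncc4nc(Nc5ccc(F)cc5)n([C@H]5CCNC5)c4n3)cc2)CC1` changes the same place, with pyrrolidin-3-yl in place of 1-((hydroxymethyl)carbonyl)pyrrolidin-3-yl on an aromatic nitrogen. The large measured step shows that the number can move strongly with a change at this nitrogen. Among the compounds with values here, that step exchanged the non-aromatic ring for a phenyl and kept the (hydroxymethyl)carbonyl unit, however, so no measured pair shows what losing this unit alone does.

Within the data shown here, compound 1, at 350 nM, is the only measured compound with a five-membered non-aromatic ring at this place, so the expectation stays close to it. No direction can be argued from the data, and no step beyond the scatter is expected in this assay, although the uncertainty is wide. The expected step is a 1.2-fold lower number from compound 1 to compound 3 (0.07 log units; within the scatter). For compound 3 the estimated value is 300 nM, with an expected range from 70 nM to 1300 nM.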

Compound 3, half-maximal inhibitory concentration: 1220 nM
Compound 3: the middle estimate sits 4.1-fold (0.61 log units) below what was measured; the measured number falls inside the stated range.
By their numbers in this assay, from the lowest: compound 2; then compound 1; then compound 3.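

In this assay, going by these compounds alone, the pair of compound 1 and compound 3 is the first to separate the (hydroxymethyl)carbonyl unit from the ring that carries it: with the pyrrolidin-3-yl ring kept, removing the unit gives a 3.5-fold higher number from compound 1 to compound 3 (0.54 log units; beyond the scatter) and so makes the compound a weaker inhibitor. This modest step is far smaller than a 160-fold higher number from compound 2 to compound 3 (2.21 log units; beyond the scatter), where the ring and its substituent differ together, so losing the unit alone does not reproduce the size of that larger difference. Nothing given here accounts for either step.

Going by these compounds, it remains open how an acetyl group or a methyl group on the pyrrolidine nitrogen would compare with the (hydroxymethyl)carbonyl unit, and so whether the hydroxyl or the carbonyl of that unit matters more. On these data alone, it is equally open how much of the low number of compound 2 belongs to the phenyl ring itself, a question that a plain phenyl or a 3-aminophenyl group at this nitrogen would address.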